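Dichlorophenyl for Methylphenyl in a Pyrazoline Thiourea Series

This account rests on a few compounds, and the source may have more. Where it says the series, first, only, none or still open, it means among the compounds named here.

Three compounds share a core and were tested in a functional assay on WM 266-4 cells (Homo sapiens) for antiproliferative activity, read by MTT assay, with a stated time of 48 h; on this read-out lower numbers stand for stronger inhibition of growth and higher numbers for weaker inhibition of growth. Compound 1 `S=C(Nc1ccccc1)N1N=C(c2ccccc2)CC1c1ccc2c(c1)OCCO2` gives 3180 nM, compound 2 `Cc1ccc(C2=NN(C(=S)Nc3ccccc3)C(c3ccc4c(c3)OCCO4)C2)cc1` gives 10300 nM, and compound 3 `COc1ccccc1C1=NN(C(=S)Nc2ccccc2)C(c2ccc3c(c2)OCCO3)C1` gives 25800 nM. Compound 2 thus stands second highest of the three, above compound 1 and below compound 3. The steps among them are all modest: a 3.2-fold higher number from compound 1 to compound 2 (0.51 log units; beyond the scatter), an 8.1-fold higher number from compound 1 to compound 3 (0.91 log units; beyond the scatter) and a 2.5-fold higher number from compound 2 to compound 3 (0.40 log units; beyond the scatter).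

Compound 4 `S=C(Nc1ccccc1)N1N=C(c2ccc(Cl)c(Cl)c2)CC1c1ccc2c(c1)OCCO2` differs from compound 2 in one place: 3,4-dichlorophenyl in place of 4-methylphenyl on a carbon with a double bond to nitrogen. Among the compounds with values here, the steps that bear on this change are a 3.2-fold higher number from compound 1 to compound 2 (0.51 log units; beyond the scatter) and an 8.1-fold higher number from compound 1 to compound 3 (0.91 log units; beyond the scatter), both of which show that substitution on this aryl group raised the number in this assay, and the step from compound 2 to compound 3 shows the size of a swap between two substituted aryl groups. Within the data shown here, no measured compound carries a halogen on this ring, so the direction of the new swap is uncertain, and the expected step is a 1.2-fold higher number from compound 2 to compound 4 (0.07 log units; within the scatter), roughly within the scatter. Compound 4 is therefore estimated to give 12000 nM in this assay, with a range from 3500 nM to 40000 nM.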

Compound 4, concentration for 50% growth inhibition: 58700 nM
The estimate for compound 4 lay 4.9-fold (0.69 log units) below the measured number; the measured number lies above the stated range.
By their numbers in this assay, from the lowest: compound 1; then compound 2; then compound 3; then compound 4.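

In this assay, 3,4-dichlorophenyl at this position did not stay level with 4-methylphenyl but raised the number further (a 5.7-fold higher number from compound 2 to compound 4 (0.76 log units; beyond the scatter)), and it also went past 2-methoxyphenyl (a 2.3-fold higher number from compound 3 to compound 4 (0.36 log units; beyond the scatter)). Against the unsubstituted phenyl group the change is the largest step in the set (an 18-fold higher number from compound 1 to compound 4 (1.27 log units; beyond the scatter)), which makes compound 4 the weakest of the four. All three substituted aryl groups now stand above phenyl, with no exception among these compounds, and the first halogen on this ring follows that pattern. Nothing measured here accounts for this order.

The compounds shown leave open whether a single chlorine gives a step of the same size, and whether an amine or a carboxylic acid on this aryl group would bring the number below that of compound 1. They also leave open how the series responds to changes elsewhere on the shared core.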